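A few compounds are considered here, and "the series" means these few. Any claim that something is new, unique, unknown or untested is made for them only; others in the source may bear on it.

Working notes on the series. Compound 1 `CCCCCC1(C(N)=O)CCC=[N+]1[O-]` gives 2.72 in a physicochemical assay for lipophilicity, in phosphate buffer, measured as octanol-water partition, at pH 7.0; a lower number here means a more polar compound, a higher number a more lipophilic compound. Within the data shown here, compound 2 `CC1(C(N)=O)CCC=[N+]1[O-]` gives 0.016 in this assay, and so stands lowest of the two numbers measured so far, its only neighbour being compound 1, which sits well above it. Among the measured compounds shown here, the single step available, a number 2.70 log units lower from compound 1 to compound 2 (beyond the scatter), is the only reference for what follows. Compound 3 `CCCCC1(C(N)=O)CCC=[N+]1[O-]` is not yet measured. Its change from compound 2 is propyl in place of hydrogen on a saturated chain carbon bound to a saturated ring carbon. This runs the measured step largely in reverse, since the entering propyl is shorter than the butyl that left; a rise in this assay is expected, beyond the scatter but somewhat smaller than the measured drop. The step implied by the estimate, a number 1.98 log units higher from compound 2 to compound 3 (beyond the scatter), is expected to be large. Compound 3 is therefore estimated at 2, with a range from 1.6 to 2.5.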

Compound 3, partition coefficient: 0.668
Compound 3: middle estimate off by 1.33 log units, on the high side; the measured number lies below the stated range.
By their numbers in this assay, from the lowest: compound 2; then compound 3; then compound 1.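

At this position the number in this assay does not climb evenly with the chain: methyl to butyl gives a number 0.65 log units higher from compound 2 to compound 3 (beyond the scatter) and the outer change, hydrogen in place of methyl four bonds along the chain from the saturated ring carbon, gives a number 2.05 log units lower from compound 1 to compound 3 (beyond the scatter). The larger share of a number 2.70 log units lower from compound 1 to compound 2 (beyond the scatter) therefore lies in that single outer change and not in the propyl added to compound 2. No measurement bearing on the reason for this uneven rise is available.

As far as these compounds go, these three compounds show straight chains only, so a longer chain, a branched chain such as isopropyl, or a chain ending in a phenyl ring remains open. Also open, from the compounds shown here alone, is how a carboxylic acid or an amine at this position would read, since the amide stays the same throughout.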